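The source may report more compounds than this note shows. Statements on the series, on what has been measured and on what is new or still open speak of the compounds shown alone.

Compound 1 `COc1cc2ccc(=O)oc2cc1OCCCCOc1no[n+]([O-])c1S(=O)(=O)c1ccccc1` was tested in an ADME assay on L02 cells (Homo sapiens) for cytotoxicity, read by MTT assay, with a stated time of 48 h (on this read-out lower numbers stand for stronger inhibition and higher numbers for weaker inhibition), where compound 1 gives 9330 nM. Compound 2 `COc1cc2cc(NC(C)=O)c(=O)oc2cc1OCCOc1no[n+]([O-])c1S(=O)(=O)c1ccccc1` gives 10300 nM in this assay. Of the two numbers shown, compound 1 carries the lower one, but the gap to compound 2 lies within the scatter, so the two cannot be told apart. Compound 3 `COc1cc2cc(NC(C)=O)c(=O)oc2cc1OCCCCOc1no[n+]([O-])c1S(=O)(=O)c1ccccc1` differs from compound 1 by acetamido in place of hydrogen on an aromatic carbon. Going by the values given here, no measured pair isolates this change, so in this assay a step no larger than the scatter, in no particular direction, is expected, and the estimated step is a 1.0-fold higher number from compound 1 to compound 3 (0.01 log units; within the scatter). Compound 3 is expected to give 9500 nM, with a range from 4500 nM to 20000 nM.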

Compound 3, half-maximal inhibitory concentration: 9190 nM
The estimate for compound 3 lay 1.0-fold (0.01 log units) above the measured number, and the stated range covers the measured number.
By their numbers in this assay, from the lowest: compounds 3, 1 and 2 (each within the scatter of the next).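

In this assay, going by these compounds alone, the step of a 1.0-fold lower number from compound 1 to compound 3 (0.01 log units; within the scatter) is the first reading of acetamido in place of hydrogen on this aromatic carbon, two atoms from the ring oxygen. It shows that, on the core of compound 1, this change leaves the number within the scatter. Nothing measured here bears on the reason for this result.

On these data alone, whether a free amine or a carboxylic acid on this carbon would also stay within the scatter remains open. So does whether acetamido would behave the same way with a different chain.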